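The compounds below may be only part of what the source reports. "The series", "measured", "known", "first", "only" and "open" are said of these compounds alone.

Measured compounds:
- compound 1 `Cc1nc(N(C)c2ccc([Se]C#N)c(Cl)c2)c2ccccc2n1` gives 11 nM in a functional assay on RKO cells (Homo sapiens) for inhibition, read by MTT assay, with a stated time of 48 h; on this read-out higher numbers stand for weaker inhibition and lower numbers for stronger inhibition
- compound 2 `COc1ccc(N(C)c2nc(C)nc3ccccc23)cc1C(=O)OCCC[Se]C#N` gives 1140 nM in this assay
- compound 3 `COc1ccc(N(C)c2nc(C)nc3ccccc23)cc1OCCCCC[Se]C#N` gives 3560 nM in this assay

Among these three, compound 3 stands at the highest number: compound 2 is the nearest, and compound 1 lies furthest away with a much lower number. Within the data shown here, the only step between neighbours that differ in one place is a 3.1-fold higher number from compound 2 to compound 3 (0.49 log units; beyond the scatter), which concerns the tail on the shared core.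

Compound 4 `COc1ccc(N(C)c2nc(C)nc3ccccc23)cc1OCCCCCC[Se]C#N` has not yet been measured. It differs from compound 3 by a group of 4 heavy atoms (2 carbon, 1 nitrogen, 1 selenium; no ring) in place of a group of 3 heavy atoms (1 carbon, 1 nitrogen, 1 selenium; no ring), on a saturated chain carbon, five bonds along the chain from an oxygen on an aromatic ring. Among the measured compounds shown here, no measured pair shows a change of exactly this kind; the step from compound 2 to compound 3 is the only one in the same region and it was modest, so it offers at best a loose guide. The expectation is therefore a step of a 1.2-fold higher number from compound 3 to compound 4 (0.07 log units; within the scatter) in this assay, at most modest and likely within the scatter, with a slight lean toward a higher number.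

Compound 4 is estimated to give 4200 nM in this assay, within a range from 1500 nM to 12000 nM.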

Compound 4, half-maximal inhibitory concentration: 1540 nM
Estimate against measurement, compound 4: 2.7-fold (0.44 log units) above, and the stated range covers the measured number.
By their numbers in this assay, from the lowest: compound 1; then compounds 2 and 4 (each within the scatter of the next); then compound 3.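

In this assay, the group of 4 heavy atoms in place of the group of 3 heavy atoms gives a 2.3-fold lower number from compound 3 to compound 4 (0.36 log units; beyond the scatter), which shows that this place on the saturated chain responds to a small extension, and that the response is toward stronger inhibition. The difference between the tails seen earlier no longer holds for the extended chain: the result is a 1.4-fold higher number from compound 2 to compound 4 (0.13 log units; within the scatter), so these two tails cannot be told apart on this read-out. No measurement shown here accounts for the change in the number.

Going by these compounds, a single step along the chain gives no trend, so it remains open whether a longer chain would carry on in the same direction or reverse it. The compounds shown also leave open how an amine or a carboxylic acid at the chain end would compare.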